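Phenyl for ethyl on the ring nitrogen of compound 3

The source may report more compounds than this note shows. Statements on the series, on what has been measured and on what is new or still open speak of the compounds shown alone.

Of the compounds shown here, three sharing one core have been tested in a functional assay on the whole organism for inhibition, with Rattus norvegicus as the target, with a stated time of 3.5 h, at a dose of 100 mg/kg by the oral route; on this read-out lower numbers stand for less inhibition and higher numbers for more inhibition at the one dose given (going by the name of the read-out). Compound 1, `CCNc1nnc(-c2nsc3ccccc23)o1`, gives 29%. Compound 2, `Clc1ccc(Nc2nnc(-c3nsc4ccccc34)o2)cc1`, gives 10%. Compound 3, `CCn1c(S)nnc1-c1nsc2ccccc12`, gives 32%. On these numbers compound 3 and compound 1 lie within the scatter of each other, while compound 2 lies beyond the scatter below both.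

Going by the values given here, the one step among the measured compounds is a number 19 percentage points lower from compound 1 to compound 2 (beyond the scatter). This bears directly on the untested compound 4, `Sc1nnc(-c2nsc3ccccc23)n1-c1ccccc1`, which differs from compound 3 by phenyl in place of ethyl on an aromatic nitrogen. In both cases an ethyl on a nitrogen gives way to an aromatic six-membered carbon ring, although in compound 4 the ring carries no chlorine and sits on a ring nitrogen rather than an amine nitrogen, so the earlier step is a guide rather than a copy.

Given that precedent, compound 4 is expected to fall below compound 3 in this assay by a step of about a number 14 percentage points lower from compound 3 to compound 4 (beyond the scatter), beyond the scatter though smaller than the step seen between compound 1 and compound 2. Compound 4 is therefore estimated at 18%, with a plausible range from 5% to 32%.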

Compound 4, a percentage reported as inhibition, in the whole organism at one dose (the size of the read-out at that dose, not a potency): 10%
Compound 4: the middle estimate sits 8 percentage points above what was measured; the range from low to high includes it.
By their numbers in this assay, from the lowest: compounds 2 and 4 (each within the scatter of the next); then compounds 1 and 3 (each within the scatter of the next).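

In this assay, phenyl in place of ethyl on an aromatic nitrogen of the five-membered aromatic ring with 3 nitrogen gives a number 22 percentage points lower from compound 3 to compound 4 (beyond the scatter) in this series, so this ring nitrogen is a place where the exchange has a clear effect on the read-out. The earlier pair gave a number 19 percentage points lower from compound 1 to compound 2 (beyond the scatter) on going to 4-chlorophenyl on an amine nitrogen, which left the aromatic ring and its chlorine together in one change, whereas the new pair shows a fall beyond the scatter with a phenyl that carries no chlorine, on a different kind of nitrogen and in a compound that also bears the sulfanyl group. No independent measurement shown here accounts for the lower number at this position, and the result therefore stands as an observation only.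

The compounds shown leave open whether a longer chain such as butyl, or a benzyl group, on this ring nitrogen would stay with ethyl or fall with phenyl. They also leave open whether a chlorine on this phenyl, or an amine in place of the sulfanyl group, would shift the number further.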